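Compound 3: 4-Fluorophenyl in Place of 3-Methylphenyl

This account rests on a few compounds, and the source may have more. Where it says the series, first, only, none or still open, it means among the compounds named here.

Compound 1 `Cc1ccc(C(=O)NN2C(=O)NC3(CC3(C)C)C2=O)cc1`: 100 mg/kg
Compound 2 `Cc1cccc(C(=O)NN2C(=O)NC3(CC3(C)C)C2=O)c1`: 100 mg/kg

In a functional assay on the whole organism (Hindlimb) for inhibition, with Mus musculus as the target, with a stated time of 0.5 h (on this read-out lower numbers stand for an effect already at smaller amounts and higher numbers for an effect only at larger amounts of compound), compound 1 gives 100 mg/kg, and compound 2 gives 100 mg/kg. Among the compounds with values here, the one measured step, no change at the digits printed from compound 1 to compound 2 (within the scatter), left the dose unchanged, so compound 2 stands level with compound 1. Compound 3 `CC1(C)CC12NC(=O)N(NC(=O)c1ccc(F)cc1)C2=O` differs from compound 2 by 4-fluorophenyl in place of 3-methylphenyl on a carbonyl carbon. Within the data shown here, no measured step involves a fluorine, and the single step seen shows no movement, so the step from compound 2 to compound 3 is expected to be none beyond the scatter, no change at the digits printed from compound 2 to compound 3 (within the scatter). Compound 3 is therefore estimated at 100 mg/kg, within 50 mg/kg to 200 mg/kg.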

Compound 3, minimum effective dose: 100 mg/kg
Estimate against measurement, compound 3: no gap at the digits printed, within the range that was stated.
By their numbers in this assay, from the lowest: compounds 1, 2 and 3 (each within the scatter of the next).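

The first fluorine on the ring leaves the dose where it was: 4-fluorophenyl in place of 3-methylphenyl gives no change at the digits printed from compound 2 to compound 3 (within the scatter), and fluoro in place of methyl on an aromatic carbon gives no change at the digits printed from compound 1 to compound 3 (within the scatter). At this place, then, the read-out does not separate a methyl group from a fluorine, at least among these three compounds. No further measurement bears on this result.

From the compounds shown here alone, whether an amine, a carboxylic acid or a longer chain on the phenyl ring would move the minimum effective dose stays open. So does whether any change here can lower it.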